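The compounds below may be only part of what the source reports. "The series", "measured", "known", "first", "only" and "open" are said of these compounds alone.

In a functional assay on CHO cells for antagonist activity at sphingosine 1-phosphate receptor 2 (Homo sapiens), read by fluorescence and calcium flux, with a stated time of 3 min (on this read-out lower numbers stand for stronger inhibition and higher numbers for weaker inhibition), compound 1 `Cc1cc(NNC(=O)Nc2cc(Cl)nc(Cl)c2)ncc1N(C)C` gives 3600 nM. Compound 2 `Cc1cc(CO)nc(NNC(=O)Nc2cc(Cl)nc(Cl)c2)c1` reaches only a limit in this assay, namely > 6600 nM (the limit of > 6600 nM in this assay, at which 1 of the 3 values shown sits). Compound 3 `Cc1cc(NNC(=O)Nc2cc(Cl)nc(Cl)c2)ncc1-c1cn(C)nc1C` also reaches only a limit, namely > 1400 nM (the limit of > 1400 nM in this assay, at which 1 of the 3 values shown sits). Going by the values given here, the single measured step, a step that the limit leaves unreadable from compound 1 to compound 3, is therefore of unknown size, and it alters a different position from the one changed here. Compound 4 `Cc1cc(NNC(=O)Nc2cc(Cl)nc(Cl)c2)nc(-c2ccc(F)cc2)c1` differs from compound 2 by 4-fluorophenyl in place of hydroxymethyl on an aromatic carbon. Among the compounds with values here, no measured step touches this exchange. The step of an at least 1.1-fold lower number from compound 2 to compound 4 (0.04 log units; that floor lies within the scatter) is expected to stay within the scatter, with a real chance that compound 4 again returns only a limit. Compound 4 is accordingly estimated at 6000 nM, with a range from 1500 nM to 25000 nM.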

Compound 4, half-maximal inhibitory concentration: 1300 nM
Compound 4: the middle estimate sits 4.6-fold (0.66 log units) above what was measured, and the stated range ends above it.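

At this place next to the ring nitrogen, 4-fluorophenyl in place of hydroxymethyl gives an at least 5.0-fold lower number from compound 2 to compound 4 (0.70 log units; beyond the scatter) in this assay. The position therefore accepts an aromatic ring without loss of inhibition, and compound 4 returns a number rather than a limit. The true size of the step stays unknown because compound 2 stands at a limit: the limit of > 6600 nM in this assay, at which 1 of the 4 values shown sits.

From the compounds shown here alone, it remains open whether the fluorine or the ring itself accounts for the step. Going by these compounds, how a plain phenyl, a pyridine or an amine would read at this position also remains open.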